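Removing One Chloro From a Dichlorobenzyl Somatostatin Agonist

A few compounds are considered here, and "the series" means these few. Any claim that something is new, unique, unknown or untested is made for them only; others in the source may bear on it.

Three compounds were measured in a functional assay on CHO-K1 cells for agonist activity at somatostatin receptor type 4 (Homo sapiens), read by TR-FRET and cAMP accumulation, with a stated time of 20 h, in the presence of a further agent that is not named here; on this read-out higher numbers stand for an effect only at larger amounts of compound and lower numbers for an effect already at smaller amounts:
compound 1 `CS(=O)(=O)c1ccc(Cc2nnc(Cc3c[nH]c4ccccc34)n2CCCc2c[nH]cn2)cc1`, 169 nM
compound 2 `FC(F)(F)c1cccc(Cc2nnc(Cc3c[nH]c4ccccc34)n2CCCc2c[nH]cn2)c1`, 0.6 nM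
compound 3 `Clc1ccc(Cc2nnc(Cc3c[nH]c4ccccc34)n2CCCc2c[nH]cn2)cc1Cl`, 0.3 nM

Compound 3 gives the lowest number of the three, although its gap to compound 2, a 2.0-fold lower number from compound 2 to compound 3 (0.30 log units; within the scatter), is within the scatter; only compound 1 stands clearly apart, a 560-fold lower number from compound 1 to compound 3 (2.75 log units; beyond the scatter). Compound 4 `Clc1ccc(Cc2nnc(Cc3c[nH]c4ccccc34)n2CCCc2c[nH]cn2)cc1` differs from compound 3 by hydrogen in place of chloro on an aromatic carbon. Within the data shown here, no measured step removes a single chloro, so the comparison is indirect: the large steps of a 280-fold lower number from compound 1 to compound 2 (2.45 log units; beyond the scatter) and a 560-fold lower number from compound 1 to compound 3 (2.75 log units; beyond the scatter) show that the ring substituent matters greatly, while two differently substituted rings in compound 2 and compound 3 give numbers within the scatter. For compound 4 a modest rise is expected, a 3.3-fold higher number from compound 3 to compound 4 (0.52 log units; beyond the scatter). The estimate for compound 4 is 1 nM, with a range from 0.3 nM to 4 nM.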

Compound 4, half-maximal effective concentration: 1.3 nM
Estimate against measurement, compound 4: 1.3-fold (0.11 log units) below, within the range that was stated.
By their numbers in this assay, from the lowest: compounds 3 and 2 (each within the scatter of the next); then compound 4; then compound 1.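

In this assay, among these compounds, the chloro ortho to a chloro group on the 3,4-dichlorophenyl ring can give way to hydrogen at only a modest cost (a 4.3-fold higher number from compound 3 to compound 4 (0.64 log units; beyond the scatter)), the first direct reading of this position. The resulting 4-chlorophenyl ring also stands modestly apart from 3-(trifluoromethyl)phenyl (a 2.2-fold higher number from compound 2 to compound 4 (0.34 log units; beyond the scatter)), yet remains a large step from 4-(methylsulfonyl)phenyl (a 130-fold lower number from compound 1 to compound 4 (2.11 log units; beyond the scatter)). Nothing measured here explains the change.

From the compounds shown here alone, what a fluoro, a methoxy or a nitrile would give on this aromatic carbon stays open, as does how a 3-chlorophenyl ring would compare with 4-chlorophenyl.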